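Swapping isopropoxycarbonyl for 2,2,2-trifluoroethyl: clearance notes

This account rests on a few compounds, and the source may have more. Where it says the series, first, only, none or still open, it means among the compounds named here.

Values so far in an ADME assay on microsomes (Homo sapiens) for metabolic stability; on this read-out higher numbers stand for fast clearance and lower numbers for slow clearance
- compound 1 (`CCOC(=O)c1ccccc1C(=O)N1C[C@H](Oc2cc(C#N)ccn2)CC[C@H]1C`) reads 37 mL/min/kg
- compound 2 (`CC(C)OC(=O)c1ccccc1C(=O)N1C[C@H](Oc2cc(C#N)ccn2)CC[C@H]1C`) reads "not determined" (no result reported)

Compound 2 has no number, so it offers no starting value and its standing on this read-out cannot be stated. The next structure is compound 3 (`C[C@@H]1CC[C@@H](Oc2cc(C#N)ccn2)CN1C(=O)c1ccccc1CC(F)(F)F`), which remains unmeasured. The change is 2,2,2-trifluoroethyl in place of isopropoxycarbonyl on an aromatic carbon and it sits on an aromatic carbon of a six-membered aromatic ring of carbon only, ortho to a large group. Among the measured compounds shown here, no measured step covers this replacement, so the size of the move rests on judgement alone. For the measured compounds named here, the only available anchor is compound 1 at 37 mL/min/kg and that compound carries an ethyl analogue of the leaving group. In this assay a moderate move towards slower clearance is expected relative to that anchor, not far beyond the usual scatter, although no measurement here shows the direction. For compound 3 the estimated clearance is 24 mL/min/kg (10 mL/min/kg to 52 mL/min/kg).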

Compound 3, clearance in the Homo sapiens assay: 132 mL/min/kg
Beside the measured number, compound 3's estimate is 5.5-fold (0.74 log units) below it; measured number above the stated range.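

In the Homo sapiens assay, 2,2,2-trifluoroethyl in place of ethoxycarbonyl on this aromatic carbon takes compound 1 at 37 mL/min/kg to compound 3 at 132 mL/min/kg, which gives a 3.6-fold higher number from compound 1 to compound 3 (0.55 log units; beyond the scatter) and moves the series towards fast clearance, so this position, ortho to a large group, can shift clearance, a point compound 1 alone could not show. The step between compound 2 and compound 3 cannot be read on clearance, while in a physicochemical assay for solubility, at pH 7 (on this read-out lower numbers stand for lower solubility and higher numbers for higher solubility), compound 2 gives 115000 nM and compound 3 gives 95000 nM, and the swap from isopropoxycarbonyl to 2,2,2-trifluoroethyl gives a 1.2-fold lower number from compound 2 to compound 3 (0.08 log units; within the scatter) and so separates the two groups on solubility no more than repeat measurements would. Nothing available accounts for the rise in clearance.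

The compounds shown leave open whether that rise goes with the loss of the ester or with the arrival of 2,2,2-trifluoroethyl, and a single pair of compounds cannot divide the two. A plain ethyl group, a methoxy group or a carboxylic acid on the same aromatic carbon would help to separate these readings, and the clearance of the isopropoxycarbonyl group remains an open point beside that of ethoxycarbonyl.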